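Amide nitrogen substituent changes on the shared core

The source may hold more compounds than are shown below. What is called first, only, known or untested is meant among the compounds shown, and "the series" means these compounds.

Compound 3 `Cc1cc(C(=O)NC2CC2)nn1Cc1cc(Cl)cc2cc(-c3ccccc3)oc12` gives 5.01 nM in an assay on CHO-K1 cells for displacement of a labelled ligand from prostaglandin E2 receptor EP1 subtype (Homo sapiens), read by scintillation counting, with a stated time of 45 min (on this read-out lower numbers stand for stronger inhibition and higher numbers for weaker inhibition), and sits at the low end of the three measured numbers, although compound 1 `Cc1cc(C(=O)NC(C)C)nn1Cc1cc(Cl)cc2cc(-c3ccccc3)oc12` with 10 nM and compound 2 `Cc1cc(C(=O)NC(C)(C)C)nn1Cc1cc(Cl)cc2cc(-c3ccccc3)oc12` with 10 nM both lie within the scatter of it. The steps touching the amide nitrogen are a 2.0-fold lower number from compound 1 to compound 3 (0.30 log units; within the scatter) and a 2.0-fold lower number from compound 2 to compound 3 (0.30 log units; within the scatter), with no change at the digits printed from compound 1 to compound 2 (within the scatter) between the two open-chain groups; none of them passes the scatter. Compound 4 `Cc1cc(C(=O)NCC2CCNCC2)nn1Cc1cc(Cl)cc2cc(-c3ccccc3)oc12` carries (piperidin-4-yl)methyl in place of cyclopropyl on an amide-type nitrogen. Within the data shown here, no measured step covers a group of this size or a ring with a hetero atom on this nitrogen, so the expectation rests only on the flat response to the three small groups and stays uncertain. A modest rise in the number is expected, a 3.0-fold higher number from compound 3 to compound 4 (0.48 log units; beyond the scatter). Compound 4 is estimated at 15 nM, range 4 nM to 60 nM.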

Compound 4, half-maximal inhibitory concentration: 20 nM
Compound 4: middle estimate off by 1.3-fold (0.12 log units), on the low side, within the range that was stated.
By their numbers in this assay, from the lowest: compounds 3, 1, 2 and 4 (each within the scatter of the next, the first and the last beyond it).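

In this assay, among these compounds, the amide nitrogen tolerates (piperidin-4-yl)methyl, a six-membered non-aromatic ring with 1 hetero atom, and the step from cyclopropyl is the first at this position beyond the scatter (a 4.0-fold higher number from compound 3 to compound 4 (0.60 log units; beyond the scatter)). Against the open-chain groups, the change stays within the scatter (a 2.0-fold higher number from compound 1 to compound 4 (0.30 log units; within the scatter); a 2.0-fold higher number from compound 2 to compound 4 (0.30 log units; within the scatter)), so only the comparison with cyclopropyl separates. No evidence at hand bears on the origin of this step.

From the compounds shown here alone, whether the ring nitrogen matters remains open, and cyclohexylmethyl on the amide nitrogen would address this. Going by these compounds, the effect of a longer chain between the amide nitrogen and the piperidine ring also remains open.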